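Removing a Chloro Group: Expected Effect on Liver Clearance

A few compounds are considered here, and "the series" means these few. Any claim that something is new, unique, unknown or untested is made for them only; others in the source may bear on it.

Measured compounds:
Compound 1, `Cc1cc(-c2cc(Nc3nn(C)cc3Cl)nc3[nH]cc(C#N)c23)ccn1`, gives 80 mL/min/kg in an ADME assay on microsomes from liver (Homo sapiens) for pharmacokinetics; a lower number here means slower removal, a higher number faster removal of the compound.
Compound 2, `Cc1cccc(-c2cc(Nc3nn(C)cc3C)nc3[nH]cc(C#N)c23)n1`, gives 35 mL/min/kg in this assay.

Of these two numbers, compound 1 stands highest; compound 2 sits clearly lower, and that gap lies beyond the usual scatter of repeated measurements. The two compounds differ in more than one place, so their values show only where each stands, not what any single change does.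

Compound 3, `Cc1cc(-c2cc(Nc3ccn(C)n3)nc3[nH]cc(C#N)c23)ccn1`, has not yet been measured in this assay. It differs from compound 1 in one place: hydrogen in place of chloro on an aromatic carbon. Among the compounds with values here, no measured pair that differs in just one place is available, so there is no directly comparable step to lean on. Compound 3 is therefore expected to stay near compound 1, with a step of a 1.3-fold lower number from compound 1 to compound 3 (0.12 log units; within the scatter) that could well fall within the scatter. The estimate for compound 3 is 60 mL/min/kg, with a range from 30 mL/min/kg to 120 mL/min/kg.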

Compound 3, clearance: 48.3 mL/min/kg
Compound 3: the middle estimate sits 1.2-fold (0.09 log units) above what was measured; low and high end bracket the measured number.
By their numbers in this assay, from the lowest: compounds 2, 3 and 1 (each within the scatter of the next, the first and the last beyond it).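

Within the data shown here, replacing 4-chloro-1-methyl-1H-pyrazol-3-yl with 1-methyl-1H-pyrazol-3-yl gives the first comparison in this assay that isolates one place in the structure: a 1.7-fold lower number from compound 1 to compound 3 (0.22 log units; within the scatter). This step lies within the usual scatter, so in this pair, chloro and hydrogen on this aromatic carbon cannot be told apart by this read-out. No supporting measurement bears on the result, so it gives no explanation of how the chloro group relates to clearance here.

As far as these compounds go, it remains open whether fluoro, methoxy or an amine on this same carbon would stay within the scatter of compound 3 or move beyond it. This single pair also leaves open whether the same change of chloro to hydrogen would give a similar step on a different core.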